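The source may hold more compounds than are shown below. What is called first, only, known or untested is meant among the compounds shown, and "the series" means these compounds.

Among the measured compounds shown here, in a functional assay on MKN-45 cells (Homo sapiens) for inhibition, with a stated time of 72 h (on this read-out higher numbers stand for weaker inhibition and lower numbers for stronger inhibition), compound 1 `COc1ccc(S(=O)(=O)N2CCc3cccc(-c4ccc(F)nc4)c32)cc1` gives 145 nM, the highest of the three numbers measured so far. Compound 2 `COc1ccc(S(=O)(=O)N2CCc3cccc(-c4ccco4)c32)cc1` gives 42 nM, and compound 3 `COc1ccc(S(=O)(=O)N2CCc3cccc(-c4ccc([N+](=O)[O-])cc4)c32)cc1` gives 34 nM. Both steps away from compound 1 lower the number: a 3.5-fold lower number from compound 1 to compound 2 (0.54 log units; beyond the scatter) and a 4.3-fold lower number from compound 1 to compound 3 (0.63 log units; beyond the scatter). Between compound 2 and compound 3 the difference is a 1.2-fold lower number from compound 2 to compound 3 (0.09 log units; within the scatter). Compound 4 `COc1ccc(-c2cccc3c2N(S(=O)(=O)c2ccc(OC)cc2)CC3)cc1` has not yet been measured in this assay. It differs from compound 1 in one place: 4-methoxyphenyl in place of 6-fluoropyridin-3-yl on an aromatic carbon. The closest measured guide is the step to compound 3, where 4-nitrophenyl, also a six-membered aromatic ring of carbon only, takes the same place, and that step was modest. The step to compound 2, a ring of a different kind, was also modest and in the same direction. A step of similar size and direction is therefore expected: a 3.6-fold lower number from compound 1 to compound 4 (0.56 log units; beyond the scatter). Compound 4 is expected to give about 40 nM in this assay, most likely between 15 nM and 120 nM.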

Compound 4, half-maximal inhibitory concentration: 211 nM
Compound 4: the middle estimate sits 5.3-fold (0.72 log units) below what was measured, and the stated range ends below it.
By their numbers in this assay, from the lowest: compounds 3 and 2 (each within the scatter of the next); then compounds 1 and 4 (each within the scatter of the next).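

At this position on the shared core, a six-membered aromatic ring of carbon only does not by itself bring a low number in this assay: what the ring carries counts, as methoxy in place of nitro gives a 6.2-fold higher number from compound 3 to compound 4 (0.79 log units; beyond the scatter). Putting 4-methoxyphenyl in place of furan-2-yl gives a step of similar size, a 5.0-fold higher number from compound 2 to compound 4 (0.70 log units; beyond the scatter), whereas putting it in place of 6-fluoropyridin-3-yl gives only a 1.5-fold higher number from compound 1 to compound 4 (0.16 log units; within the scatter), so these two groups cannot be told apart here. Nothing available explains why methoxy and nitro on the same ring differ.

From the compounds shown here alone, it remains open whether an amine or a carboxylic acid on that phenyl ring would fall with the nitro compound or the methoxy compound. Going by these compounds, it is also open whether a thiophene ring would match the furan-2-yl result.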